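The compounds below may be only part of what the source reports. "The series", "measured", "known", "first", "only" and "open" are said of these compounds alone.

Notes on the series. Compound 1 `CN(C)c1ccc2cc(NC(=O)CCc3ccc(C(F)(F)F)cc3)ccc2n1` gives 13 nM in an assay on isolated protein for displacement of a labelled ligand from melanin-concentrating hormone receptor 1 (Homo sapiens); on this read-out higher numbers stand for weaker inhibition and lower numbers for stronger inhibition. Compound 2 `NC1CCN(c2ccc3cc(NC(=O)CCc4ccc(C(F)(F)F)cc4)ccc3n2)C1` gives 12 nM in this assay, and compound 3 `CCCN(CCC)c1ccc2cc(NC(=O)CCc3ccc(C(F)(F)F)cc3)ccc2n1` gives 490 nM in this assay. Compound 2 holds the lowest of the three numbers, but its separation from compound 1 is only a 1.1-fold lower number from compound 1 to compound 2 (0.03 log units; within the scatter), within the scatter, so the two cannot be ordered; compound 3 sits far away, with a 41-fold higher number from compound 2 to compound 3 (1.61 log units; beyond the scatter). The exchange of dimethylamino for dipropylamino gives a 38-fold higher number from compound 1 to compound 3 (1.58 log units; beyond the scatter), the single large movement seen so far, and it concerns the substituent on the aromatic carbon.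

Compound 4 `CC(=O)NC1CCN(c2ccc3cc(NC(=O)CCc4ccc(C(F)(F)F)cc4)ccc3n2)C1` differs from compound 2 by acetyl in place of hydrogen on an amine nitrogen, so that amino becomes acetamido within the 3-aminopyrrolidin-1-yl group. Going by the values given here, no measured step touches this amine nitrogen. The two large steps, to compound 3, concern the aromatic-carbon substituent, and the step from compound 1 to compound 2 shows only that replacing dimethylamino by 3-aminopyrrolidin-1-yl costs nothing beyond the scatter. Without a direct precedent, a step of modest size is expected in this assay, direction uncertain: a 2.5-fold higher number from compound 2 to compound 4 (0.40 log units; beyond the scatter). The estimate for compound 4 is therefore 30 nM, with a range of 8 nM to 120 nM.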

Compound 4, half-maximal inhibitory concentration: 5 nM
Beside the measured number, compound 4's estimate is 6.0-fold (0.78 log units) above it; measured number outside the range, below it.
By their numbers in this assay, from the lowest: compound 4; then compounds 2 and 1 (each within the scatter of the next); then compound 3.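

In this assay, going by these compounds alone, putting acetyl in place of hydrogen on the amine nitrogen lowers the number rather than raising it (a 2.4-fold lower number from compound 2 to compound 4 (0.38 log units; beyond the scatter)), a modest step beyond the scatter and the first measured change at this nitrogen. An unsubstituted amino group is therefore not needed to keep the number low, and 3-acetamidopyrrolidin-1-yl separates from dimethylamino on the aromatic carbon (a 2.6-fold lower number from compound 1 to compound 4 (0.41 log units; beyond the scatter)), which 3-aminopyrrolidin-1-yl did not do, while the distance to dipropylamino is also large (a 98-fold lower number from compound 3 to compound 4 (1.99 log units; beyond the scatter)). No measurement shown bears on why acetyl has this effect on the number.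

Going by these compounds, whether the lower number belongs to acetyl alone or extends to other groups on this nitrogen stays open, for example a propionyl, benzoyl, methanesulfonyl or methyl group. On these data alone, it is also open how far the nitrogen tolerates a longer chain or a carboxylic acid attached through the same amide link, and whether the acetyl step carries over to a core with a different side chain.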